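The source may report more compounds than this note shows. Statements on the series, on what has been measured and on what is new or still open speak of the compounds shown alone.

Working notes on the series.

Of the compounds shown here, three of the shared core have been measured in a functional assay on ZR-75-1 cells (Homo sapiens) for cytotoxicity, read by sulforhodamine B assay, with a stated time of 3 days; a higher number here means that more compound is needed for the effect, a lower number that less compound is needed. Compound 1 `Cc1coc(-c2ccc3c(c2O)CCCC3(C)C)c1CO` gives 25.5 uM. Compound 2 `CCOCc1c(C)coc1-c1ccc2c(c1OC)CCCC2(C)C` gives 19.8 uM. Compound 3 `Cc1coc(-c2ccc3c(c2O)CCC3)c1C(=O)O` gives 30.2 uM. For the measured compounds named here, compound 2 stands within the usual scatter of both compound 1 and compound 3, so no separation among the three can be read from these numbers, and no compound can be called more or less potent than another on this evidence.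

The next compound, compound 4 `COC(=O)c1c(C)coc1-c1ccc2c(c1OC)CCCC2(C)C`, has not yet been measured in this assay. Its structure differs from compound 2 at a single point on the five-membered aromatic ring: methoxycarbonyl in place of ethoxymethyl on an aromatic carbon. Going by the values given here, no pair of measured compounds differs in one place, so no measured step stands behind this change; the only guide is that the substituent at this position has varied across compound 1, compound 2 and compound 3 without any of them moving beyond the scatter of the others.

On that basis the step from compound 2 to compound 4 is expected to be a 1.3-fold higher number from compound 2 to compound 4 (0.10 log units; within the scatter), which is not beyond the scatter in either direction. Compound 4 is therefore estimated to give about 25 uM in this assay, with the likely range running from 12 uM to 50 uM.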

Compound 4, concentration for half-maximal effect: 34.5 uM
Beside the measured number, compound 4's estimate is 1.4-fold (0.14 log units) below it; the range from low to high includes it.
By their numbers in this assay, from the lowest: compounds 2, 1, 3 and 4 (each within the scatter of the next).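

For the compounds shown here, the exchange of ethoxymethyl for methoxycarbonyl gives the first reading of a single change on this aromatic carbon of the five-membered aromatic ring: in this assay it gives a 1.7-fold higher number from compound 2 to compound 4 (0.24 log units; within the scatter), so no order can be drawn between the two compounds. Both groups have 4 heavy atoms and 0 hydrogen-bond donors, while methoxycarbonyl brings a double bond outside the aromatic rings and 2 hydrogen-bond acceptors against 1; in this single pair, those differences do not produce a step beyond the scatter. No supporting measurement bears on the size of this step.

The compounds shown leave open whether an amine, an amide or a longer ether chain at this position, with the rest of compound 2 held constant, would move the number beyond the scatter. From the compounds shown here alone, it also remains open whether the exchange of ethoxymethyl for methoxycarbonyl would give a comparable step on the core of compound 1, which carries a free hydroxyl in place of the methoxy group of compound 2.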